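The source may hold more compounds than are shown below. What is called first, only, known or untested is meant among the compounds shown, and "the series" means these compounds.

Two compounds of the series have numbers in an assay on CHO cells with Alpha-2C adrenergic receptor (Homo sapiens) as the target; on this read-out lower numbers stand for smaller maximal responses and higher numbers for larger maximal responses. Compound 1, `CCOc1ccccc1OC(C)C1=NCCN1`, gives 0.45 in this assay; compound 2, `CC(C)Oc1ccccc1OC(C)C1=NCCN1`, gives 0.7. Among the measured compounds shown here, compound 1 thus stands lowest of the two numbers, with compound 2 as its only and nearest neighbour. For the measured compounds named here, the single measured step, a number 0.25 higher from compound 1 to compound 2 (beyond the scatter), concerns methyl in place of hydrogen on a saturated chain carbon bound to an oxygen on an aromatic ring and a saturated chain carbon; it lies beyond the scatter and is modest.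

Compound 3, `CC(Oc1ccccc1S(C)(=O)=O)C1=NCCN1`, awaits measurement in this assay. Relative to compound 1 the change is methylsulfonyl in place of ethoxy on an aromatic carbon, on an aromatic carbon of the six-membered ring, ortho to a group of 8 heavy atoms. Going by the values given here, no measured step touches the substituent on the aromatic ring: the step from compound 1 to compound 2 alters the chain and not the ring, so it gives no direction for this change. The expectation is therefore a step of about a number 0.050 lower from compound 1 to compound 3 (within the scatter), none beyond the scatter, but with a wide range. Compound 3 is estimated at 0.4, expected to fall between 0.15 and 0.7.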

Compound 3, intrinsic activity: the largest response reached, as a fraction of the reference agonist's: 0.6
The estimate for compound 3 lay 0.20 below the measured number; measured number inside the range.
By their numbers in this assay, from the lowest: compound 1; then compounds 3 and 2 (each within the scatter of the next).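

In this assay, among the compounds shown here, this is the first measured change at the aromatic carbon carrying the ethoxy group of compound 1, and it shows that this position affects the maximal response: methylsulfonyl in place of ethoxy gives a number 0.15 higher from compound 1 to compound 3 (beyond the scatter). Methylsulfonyl in place of isopropoxy gives a number 0.10 lower from compound 2 to compound 3 (within the scatter), so methylsulfonyl and isopropoxy cannot be told apart on this read-out, and a response of this size does not require a group attached through oxygen at this carbon. No supporting measurement bears on these steps, so their cause remains unassigned.

The compounds shown leave open how the read-out responds at this carbon to a smaller group such as methoxy, or to an amine or a carboxylic acid, each of which would test whether the response depends on the kind of group or extends to quite different ones. Also open, from the compounds shown here alone, is whether the methyl on the saturated chain carbon of the shared core, or a longer chain in its place, still matters when methylsulfonyl sits on the aromatic ring.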